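A few compounds are considered here, and "the series" means these few. Any claim that something is new, unique, unknown or untested is made for them only; others in the source may bear on it.

Measured so far in a functional assay on MIA PaCa-2 cells (Homo sapiens) for inhibition, read by MTT assay, with a stated time of 3 days; a lower number here means a stronger inhibitor, a higher number a weaker inhibitor:
Compound 1 `CCN(CC)S(=O)(=O)c1ccc(S(=O)(=O)N2CCC[C@@H](C(=O)N[C@@H]3CCN(C(=O)OC(C)(C)C)C3)C2)cc1` gives > 10000 nM, which is a limit of the assay and not a number.
Compound 2 `CCN(CC)S(=O)(=O)c1ccc(S(=O)(=O)N2CCC[C@@H](C(=O)N3CCN(c4nc(C(F)(F)F)no4)CC3)C2)cc1` gives > 10000 nM, again a limit.
Compound 3 `CCN(CC)C(=O)[C@@H]1CCCN(S(=O)(=O)c2ccc(S(=O)(=O)N(CC)CC)cc2)C1` gives > 10000 nM, likewise a limit.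

Compound 3 therefore stands exactly where the whole set stands: at the limit of > 10000 nM in this assay, at which 3 of the 3 values shown sit. Among the measured compounds shown here, no step between measured compounds can be computed, and the three values show only that none of the three reaches a measurable potency in this assay.

Compound 4 `CCN(CC)S(=O)(=O)c1ccc(S(=O)(=O)N2CCC[C@@H](C(=O)NC)C2)cc1` differs from compound 3 by methylamino in place of diethylamino on a carbonyl carbon. With every value at the limit, the expected step is a step that the limit leaves unreadable from compound 3 to compound 4, none beyond the usual scatter. Compound 4 is estimated at 20000 nM in this assay, within 8000 nM to 50000 nM, and most probably reported again only as a limit.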

Compound 4, half-maximal inhibitory concentration: > 10000 nM
Compound 4: only a limit was reported; the forecaster's own chance of this, stated with the estimate: 90%; the middle value is on the limit's open side.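

The result for compound 4 is only a limit, so the steps to it from compound 3 and from compound 1 cannot be read. In this assay the compounds shown leave open which change to the shared core, if any, brings measurable potency.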